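Urea series: sulfamoyl in place of nitro

A few compounds are considered here, and "the series" means these few. Any claim that something is new, unique, unknown or untested is made for them only; others in the source may bear on it.

Measured so far, in a functional assay on MCF7 cells (Homo sapiens) for inhibition; a lower number here means a stronger inhibitor, a higher number a weaker inhibitor:
- compound 1 `CCCCNC(=O)N1CC1C#N`: 6700 nM
- compound 2 `N#CC1CN1C(=O)Nc1ccc([N+](=O)[O-])cc1`: 3000 nM
- compound 3 `N#CC1CN1C(=O)NC1CCCCC1`: 8900 nM

Compound 2 gives the lowest of the three numbers. Its nearest neighbour is compound 1, whose number is higher by a margin beyond the usual scatter; compound 3 lies furthest away, also beyond the scatter. Within this small set the aryl urea of compound 2 is therefore the strongest inhibitor, with the butyl urea of compound 1 and the cyclohexyl urea of compound 3 both weaker.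

Compound 4 `N#CC1CN1C(=O)Nc1ccc(S(N)(=O)=O)cc1` keeps the whole of compound 2 except for one change: sulfamoyl in place of nitro on an aromatic carbon. Going by the values given here, no measured pair shows a change of this kind, so there is no direct precedent to lean on; the only guidance is that the aryl urea has so far given the lowest number.

Since the aromatic ring and the urea are retained, the expected step in this assay is small, in either direction, and most likely within the scatter. The estimated step from compound 2 to compound 4 is a 1.3-fold higher number from compound 2 to compound 4 (0.12 log units; within the scatter). For compound 4 the expected value is 4000 nM, with a range from 1500 nM to 12000 nM.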

Compound 4, half-maximal inhibitory concentration: > 15000 nM
Compound 4 was reported as a limit; the forecaster's own chance of this, stated with the estimate: 5%; at least 3.7-fold (0.57 log units) between middle value and limit.
By their numbers in this assay, from the lowest: compound 2; then compounds 1 and 3 (each within the scatter of the next). At a limit, above all of these: compound 4.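

In this assay compound 4 gives > 15000 nM, which is a limit of the assay and not a number. Sulfamoyl in place of nitro on an aromatic carbon para to a group of 8 heavy atoms gives an at least 5.0-fold higher number from compound 2 to compound 4 (0.69 log units; beyond the scatter), so this position is not a tolerant one for every group, and keeping the aromatic ring and the urea does not by itself secure a low number. The size of this step rests on a limit and not on two numbers: the limit of > 15000 nM in this assay, at which 1 of the 4 values shown sits.

Going by these compounds, the series shows only nitro and sulfamoyl at this place, so it remains open whether a methylsulfonyl group, which keeps the sulfur and both oxygens but has no nitrogen and no hydrogen-bond donor, would stay close to compound 2 or fall with compound 4. On these data alone, it is equally open whether nitro itself matters or sulfamoyl alone is poorly accepted, and an unsubstituted phenyl urea, a chloro group or an amine on that aromatic carbon would help separate the two readings.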